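Dimethylaminophenyl analogue of compound 1: solubility outlook

A few compounds are considered here, and "the series" means these few. Any claim that something is new, unique, unknown or untested is made for them only; others in the source may bear on it.

Within the data shown here, compound 1 `CCOC(=O)C1=C(C)N/C(=C/c2cc(C)n(-c3cccc(C(F)(F)F)c3)c2C)C1=O` gives 1 ug/mL in a physicochemical assay for solubility, read by nephelometry, measured as kinetic solubility, at pH 2.0 (on this read-out lower numbers stand for lower solubility and higher numbers for higher solubility), the lowest of the three numbers measured so far. Compound 3 `CCOC(=O)C1=C(C)N/C(=C/c2cc(C)n(-c3ccc(F)cc3F)c2C)C1=O` gives 3.1 ug/mL and compound 2 `CCOC(=O)C1=C(O)/C(=C\c2cc(C)n(-c3ccc(F)cc3)c2C)N=C1C` gives 6.3 ug/mL. Compound 4 `CCOC(=O)C1=C(C)N/C(=C/c2cc(C)n(-c3ccc(N(C)C)cc3)c2C)C1=O` differs from compound 1 by 4-(dimethylamino)phenyl in place of 3-(trifluoromethyl)phenyl on an aromatic nitrogen. Among the measured compounds shown here, the only measured step that bears on this, an exchange of the aryl group on the same aromatic nitrogen, is a 3.1-fold higher number from compound 1 to compound 3 (0.49 log units; beyond the scatter); compound 2 has a differently arranged core and offers no direct comparison. An aryl exchange at this position is therefore expected to raise this assay by a modest to moderate amount, and compound 4 is expected to show a 12-fold higher number from compound 1 to compound 4 (1.08 log units; beyond the scatter). The estimate for compound 4 is 12 ug/mL, with a range from 2.5 ug/mL to 60 ug/mL.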

Compound 4, solubility: 12.5 ug/mL
Compound 4: the middle estimate sits 1.0-fold (0.02 log units) below what was measured; measured number inside the range.
By their numbers in this assay, from the lowest: compound 1; then compound 3; then compounds 2 and 4 (each within the scatter of the next).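

Aryl exchange on the aromatic nitrogen reaches further in this assay than the earlier compounds showed, with a 13-fold higher number from compound 1 to compound 4 (1.10 log units; beyond the scatter) for 4-(dimethylamino)phenyl in place of 3-(trifluoromethyl)phenyl. Against the 2,4-difluorophenyl group, the same entering group gives a 4.0-fold higher number from compound 3 to compound 4 (0.61 log units; beyond the scatter) and so stands clear of both fluorinated aryl compounds on the shared core. No measurement here accounts for the rise.

On these data alone, it remains open whether the gain depends on the dimethylamino nitrogen, which a morpholine or a methoxy group at the same ring position would test. As far as these compounds go, whether it carries over to the core of compound 2 is also open.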